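The source may report more compounds than this note shows. Statements on the series, on what has been measured and on what is new or still open speak of the compounds shown alone.

Compound 3 `Cc1ccc2ncc(S(=O)(=O)c3ccccc3)c(N3CCC(C)CC3)c2c1` stands lowest of the three measured compounds in an assay on isolated protein for displacement of a labelled ligand from metabotropic glutamate receptor 5 (Homo sapiens), with a stated time of 60 min, tested at 1 uM (a higher number here means more inhibition at the concentration tested (going by the name of the read-out), a lower number less inhibition), giving 67%, while compound 1 `Cc1ccc2ncc(S(=O)(=O)c3ccc(Cl)cc3)c(N3CCC(C)CC3)c2c1` gives 79% and compound 2 `Cc1ccc2ncc(S(=O)(=O)c3ccc(C)c(Cl)c3)c(N3CCC(C)CC3)c2c1` gives 91%. Compound 4 `Cc1ccc2ncc(S(=O)(=O)c3ccc(C#N)cc3)c(N3CCC(C)CC3)c2c1` differs from compound 3 by cyano in place of hydrogen on an aromatic carbon. The measured step that bears most directly on this is a number 12 percentage points lower from compound 1 to compound 3 (beyond the scatter), in which the same aromatic carbon lost its chloro; read in reverse, a substituent entering there raised the number modestly. The steps of a number 12 percentage points higher from compound 1 to compound 2 (beyond the scatter) and a number 24 percentage points lower from compound 2 to compound 3 (beyond the scatter) likewise leave the unsubstituted phenyl at the bottom. Within the data shown here, no measured compound carries a cyano group, so the size of the effect is uncertain. Compound 4 is therefore expected to show a number 8 percentage points higher from compound 3 to compound 4 (within the scatter), landing at an estimated 75% within a range of 60% to 88%.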

Compound 4, a percentage reported as inhibition, at one concentration (the size of the read-out at that concentration, not a potency): 55%
Compound 4: the middle estimate sits 20 percentage points above what was measured; the measured number lies below the stated range.
By their numbers in this assay, from the lowest: compound 4; then compound 3; then compound 1; then compound 2.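

In this assay a group entering para to a large group does not always raise the number: a number 12 percentage points lower from compound 3 to compound 4 (beyond the scatter), so the direction of the change depends on what enters at this aromatic carbon. Cyano in place of chloro there gives a number 24 percentage points lower from compound 1 to compound 4 (beyond the scatter), and the full change of aryl group gives a number 36 percentage points lower from compound 2 to compound 4 (beyond the scatter), the largest step among these compounds. Nothing available explains why cyano and chloro part ways at this carbon. As far as these compounds go, whether a methoxy group, an amine or a carboxylic acid at this position would follow chloro or cyano remains open.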